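A Chloro Substituent on the Benzyl Ring of Compound 2

The source may hold more compounds than are shown below. What is called first, only, known or untested is meant among the compounds shown, and "the series" means these compounds.

Measured so far in a functional assay on RAW264.7 cells (Mus musculus), read by fluorescence; a lower number here means a stronger inhibitor, a higher number a weaker inhibitor:
- compound 1, `CCOC(=O)C1=CCCCC1S(=O)(=O)Cc1ccc(F)cc1Cl`, with several entries: 10 nM; 10000 nM; 5.7 nM (3 entries)
- compound 2, `CCOC(=O)C1=CCCCC1S(=O)(=O)Cc1ccccc1`: 101 nM
- compound 3, `CCOC(=O)C1=CCCCC1S(=O)(=O)Cc1ccc(Cl)cc1F`: 104 nM

The three measured compounds share one core and differ only in the benzyl ring attached to the sulfonyl group. Compound 2 carries the unsubstituted phenyl ring. In this assay compound 2 and compound 3 give numbers that lie within the usual scatter of each other, so no order can be read between them. Compound 1 has more than one entry, and its entries the several entries of compound 1 in this assay, 10 nM; 10000 nM; 5.7 nM (3 entries) spread so widely that no single number can be taken from them.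

Compound 4, `CCOC(=O)C1=CCCCC1S(=O)(=O)Cc1cccc(Cl)c1`, is not yet measured. It differs from compound 2 in one place: chloro in place of hydrogen on an aromatic carbon. The change is small, a single chlorine on an aromatic carbon. Among the compounds with values here, no step between measured compounds shows what a single chloro in this position does, and the measured pairs with halogens differ in more than one place, so no direction can be derived from them.

Compound 4 is therefore expected to land near compound 2, with a step of a 1.3-fold lower number from compound 2 to compound 4 (0.10 log units; within the scatter) that is expected to stay close to the scatter. The estimate for compound 4 in this assay is 80 nM, within a range from 20 nM to 320 nM.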

Compound 4, half-maximal inhibitory concentration: 14 nM
Compound 4: middle estimate off by 5.7-fold (0.76 log units), on the high side; the whole stated range lies above it.
By their numbers in this assay, from the lowest: compound 4; then compounds 2 and 3 (each within the scatter of the next).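

In this assay, a single chloro on an aromatic carbon of the benzyl ring brings a clear change: a 7.2-fold lower number from compound 2 to compound 4 (0.86 log units; beyond the scatter). Within the data shown here, this is the first step between measured compounds that differ in one place, so the change from phenyl to 3-chlorophenyl on the shared core now has both a direction and a size, and that size lies beyond the scatter. The earlier compounds shown here could not show this, as their halogen-bearing members differ from compound 2 in more than one place.

The compounds shown leave open whether this gain belongs to chloro itself or would also come with another group at this place, such as fluoro, methyl, methoxy or an amine, and whether chloro elsewhere on the ring would act in the same way. Compound 1, which carries a chloro together with a fluoro, does not settle this, as no single number can be taken from its spread of entries: the several entries of compound 1 in this assay, 10 nM; 10000 nM; 5.7 nM (3 entries)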